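Swapping the aryl group on the ring nitrogen

This account rests on a few compounds, and the source may have more. Where it says the series, first, only, none or still open, it means among the compounds named here.

Measured compounds and their values:
compound 1 `COc1ccc(-c2nc(CNc3ccc(C(=O)NO)cc3)n(-c3ccccc3)n2)cc1` gives > 20000 nM
compound 2 `O=C(NO)c1ccc(NCc2nc(-c3ccccc3)nn2-c2cccc(Cl)c2)cc1` gives 13700 nM
compound 3 `Cc1ccc(-c2nc(CNc3ccc(C(=O)NO)cc3)n(-c3ccccc3)n2)cc1` gives > 20000 nM

All three share one core and differ only in the aryl groups attached to it. For the measured compounds named here, in a functional assay on MGC-803 cells (Homo sapiens) for antiproliferative activity, read by MTT assay, with a stated time of 72 h (a higher number here means a weaker inhibitor, a lower number a stronger inhibitor), compound 2 is the only compound that yields a number at all. For compound 1 the value is a limit of the assay, not a number. For compound 3 the value is likewise a limit. Between compound 1 and compound 3 the change is a step that the two limits leave unreadable from compound 1 to compound 3, so this step cannot be read. Compound 2 therefore stands as the sole measured point against (the limit of > 20000 nM in this assay, at which 2 of the 3 values shown sit).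

Compound 4 `COc1ccc(-n2nc(-c3ccccc3)nc2CNc2ccc(C(=O)NO)cc2)cc1` has not yet been measured. Compared with compound 2 the change is 4-methoxyphenyl in place of 3-chlorophenyl on an aromatic nitrogen. Going by the values given here, no measured step touches the aromatic nitrogen, so nothing tells directly how this change will act. What the measured compounds do show is that the 4-methoxyphenyl group of compound 1 sits at the limit, and that only compound 2, with its 3-chlorophenyl group, gives a number. On that basis compound 4 is expected to move toward the limit, with a step of a 1.5-fold higher number from compound 2 to compound 4 (0.16 log units; within the scatter), and its estimated value is 20000 nM, within a range from 8000 nM to 45000 nM.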

Compound 4, half-maximal inhibitory concentration: 7050 nM
Compound 4: the middle estimate sits 2.8-fold (0.45 log units) above what was measured, outside the stated range (below it).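

In this assay, the change on the aromatic nitrogen is a 1.9-fold lower number from compound 2 to compound 4 (0.29 log units; within the scatter), so 3-chlorophenyl and 4-methoxyphenyl cannot be told apart at this position. For the compounds shown here, this is the first step that can be read, as the earlier step between two limits cannot. Going by these compounds alone, compound 4 gives a number, which shows that 3-chlorophenyl is not the only group on this nitrogen to do so, and that leaving a chlorine out and bringing in an oxygen with one hydrogen-bond acceptor produces no difference beyond the scatter in this pair.

Going by these compounds, whether an amine or a carboxylic acid on this aryl ring, or a longer chain in its place, would shift the number beyond the scatter stays open. The other compounds offer no further numbers for comparison, since their values are limits and not measurements: the limit of > 20000 nM in this assay, at which 2 of the 4 values shown sit.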